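This account rests on a few compounds, and the source may have more. Where it says the series, first, only, none or still open, it means among the compounds named here.

Measured compounds:
compound 1 `Cc1ccc(NC(=O)N[C@H](C)c2ccccc2)cc1` — 98%
compound 2 `Cc1ccc(NC(=O)N[C@@H](C)c2ccccc2)cc1` — 99%
compound 3 `C[C@@H](NC(=O)Nc1ccc(C(C)(C)C)cc1)c1ccccc1` — 88%

In an ADME assay on the whole organism with Oryza sativa as the target, tested at 1 uM (a lower number here means a stronger effect, a higher number a weaker effect of the compound at the concentration tested), compound 1 gives 98%, compound 2 gives 99% and compound 3 gives 88%. Compound 2 holds the highest of the three numbers; compound 1 sits nearest it, within the scatter, and compound 3 lies furthest from it, beyond the scatter. Of the two measured steps, the first is a number 1 percentage points higher from compound 1 to compound 2 (within the scatter), which is explained by the fact that compounds 1 and 2 differ only in the configuration as drawn; the second is a number 10 percentage points lower from compound 1 to compound 3 (within the scatter), where a larger alkyl group is placed on the aromatic ring of the shared core.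

The next compound, compound 4 `CCCCc1ccc(NC(=O)N[C@@H](C)c2ccccc2)cc1`, is reached from compound 2 by a single change: propyl in place of hydrogen on a saturated chain carbon bound to an aromatic carbon. This again enlarges the alkyl group on the aromatic ring, so the step from compound 1 to compound 3 is the one that bears on it; that step was small and within the scatter. Compound 4 is therefore expected to show a small decrease, a number 9 percentage points lower from compound 2 to compound 4 (within the scatter), if any beyond the scatter. Compound 4 is estimated at 90%, with a range from 78% to 100%.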

Compound 4, a percentage reported as activity, at one concentration (the size of the read-out at that concentration, not a potency): 72%
The estimate for compound 4 lay 18 percentage points above the measured number, and the stated range ends above it.
By their numbers in this assay, from the lowest: compound 4; then compounds 3, 1 and 2 (each within the scatter of the next, the first and the last beyond it).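

In this assay, propyl in place of hydrogen on a saturated chain carbon bound to an aromatic carbon, which is methyl to butyl when cut one bond further out, gives a number 27 percentage points lower from compound 2 to compound 4 (beyond the scatter). This shows that the number does respond to the group at this place, whereas the tert-butyl change gave only a number 10 percentage points lower from compound 1 to compound 3 (within the scatter). Nothing known about these compounds accounts for the size of the step, and the difference in configuration between compound 1 and compound 2 does not bear on it.

The compounds shown leave open whether a longer chain, such as hexyl, would lower the number further or whether the trend stops at butyl. They also leave open whether an amine or a carboxylic acid at the end of the chain would keep the lower number seen with compound 4.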